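A few compounds are considered here, and "the series" means these few. Any claim that something is new, unique, unknown or untested is made for them only; others in the source may bear on it.

Measured compounds:
compound 1, `NS(=O)(=O)c1cc(-c2nnc(CN3CCN(c4ccc(F)cc4)CC3)o2)c(Cl)cc1SCc1ccccc1` — in a functional assay on HCT-116 cells (Homo sapiens) for cytotoxicity, read by MTT assay, with a stated time of 72 h (on this read-out higher numbers stand for weaker inhibition and lower numbers for stronger inhibition), compound 1 gives 34000 nM
compound 2, `CC(C)(O)c1cn(Cc2nnc(-c3cc(S(N)(=O)=O)c(SCc4ccccc4)cc3Cl)o2)nn1` — in this assay compound 2 gives 82000 nM

Of the two numbers measured, compound 2 holds the higher one; compound 1 sits a good way below it, and that gap lies beyond the usual scatter of this assay. Among the compounds with values here, no step between two measured compounds that differ in a single place is available, so the only guide is what these two values show.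

Compound 3, `NS(=O)(=O)c1cc(-c2nnc(/C=C/c3ccccc3)o2)c(Cl)cc1SCc1ccccc1`, is reached from compound 2 by one change: 2-phenylethenyl in place of (4-(1-hydroxy-1-methylethyl)-1H-1,2,3-triazol-1-yl)methyl on an aromatic carbon. The new group has no hydrogen-bond donor or acceptor, where the old one had several, and nothing in the measured pair tells how such a swap plays out here. Compound 3 is therefore expected to move by about a 1.8-fold lower number from compound 2 to compound 3 (0.26 log units; within the scatter), a modest step downward that stays close to the scatter, and its value in this assay is estimated at 45000 nM, within a range from 12000 nM to 150000 nM.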

Compound 3, half-maximal inhibitory concentration: 18000 nM
Compound 3: the middle estimate sits 2.5-fold (0.40 log units) above what was measured, and the stated range covers the measured number.
By their numbers in this assay, from the lowest: compounds 3 and 1 (each within the scatter of the next); then compound 2.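

At the aromatic carbon of the five-membered ring with 2 nitrogen and 1 oxygen, putting 2-phenylethenyl in place of (4-(1-hydroxy-1-methylethyl)-1H-1,2,3-triazol-1-yl)methyl gives in this assay a 4.6-fold lower number from compound 2 to compound 3 (0.66 log units; beyond the scatter), the first single-place step available, and it lies beyond the scatter. It shows that the number responds to the group at this position, and that a group with 0 hydrogen-bond donors and 0 hydrogen-bond acceptors goes with the lower number here. Nothing measured bears on why the number falls.

This one step swaps the whole group, so the compounds shown do not separate the roles of the double bond, the carbon-only ring and the hydroxyl-bearing triazole. A saturated 2-phenylethyl chain or a simple amine at this position would be needed to tell them apart.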